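The source may hold more compounds than are shown below. What is called first, only, known or untested is meant among the compounds shown, and "the series" means these compounds.

Measured in a physicochemical assay for solubility, using the shake flask method, in simulated intestinal fluid, measured as kinetic solubility, with a stated time of 2 h, at 25 degrees C, at pH 6.5; on this read-out higher numbers stand for higher solubility and lower numbers for lower solubility:
- Compound 1 `Cc1noc(-c2nc(C)c3c(c2N)C(=O)N(Cc2ccc(Cl)cc2)C3=O)n1`: < 5000 nM, a limit of the assay and not a number.
- Compound 2 `Cc1noc(-c2nc(C)c3c(c2N)C(=O)N(C(C)c2ccccc2)C3=O)n1`: 10900 nM.

Among the measured compounds shown here, compound 2 holds the only actual number in this assay, and the other reading is the limit of < 5000 nM in this assay, at which 1 of the 2 values shown sits. Compound 3 `COc1ccccc1CN1C(=O)c2c(C)nc(-c3nc(C)no3)c(N)c2C1=O` differs from it by 2-methoxybenzyl in place of 1-phenylethyl on an amide-type nitrogen in a ring, with 2-methoxybenzyl in place of 1-phenylethyl on an amide-type nitrogen in a ring. For the measured compounds named here, one measured step bears on this change: an at least 2.1-fold higher number from compound 1 to compound 2 (0.33 log units; beyond the scatter), with 1-phenylethyl in place of 4-chlorobenzyl at the same nitrogen. Its true size is open, since one end is a limit. Compound 3 carries a benzyl group, as compound 1 does, so part of an at least 2.1-fold higher number from compound 1 to compound 2 (0.33 log units; beyond the scatter) is expected to be given back, though this rests on a single step. The expected change is a 1.6-fold lower number from compound 2 to compound 3 (0.19 log units; within the scatter), a modest move to a lower number. For compound 3 the estimated value is 7000 nM, with an expected range of 3000 nM to 16000 nM.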

Compound 3, solubility: < 5000 nM
Compound 3 was reported as a limit (the forecaster's own chance of this, stated with the estimate: 30%); at least 1.4-fold (0.14 log units) between middle value and limit.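

In this assay, from the compounds shown here alone, 2-methoxybenzyl in place of 1-phenylethyl on the amide-type nitrogen in a ring gives an at least 2.1-fold lower number from compound 2 to compound 3 (0.33 log units; beyond the scatter), and the true size of this step stays open, as the reading for compound 3 is a limit and not a number. Compound 1 and compound 3 end at the same limit, so the step between them cannot be read and gives no order for 4-chlorobenzyl and 2-methoxybenzyl: the limit of < 5000 nM in this assay, at which 2 of the 3 values shown sit. Among the compounds shown, 1-phenylethyl alone gives an actual number, now against two substituted benzyl groups rather than one.

Going by these compounds, whether that number goes with the extra methyl of 1-phenylethyl or with its unsubstituted phenyl ring remains open, and plain benzyl on this nitrogen would separate the two. Also open, on these data alone, is how a chain ending in an amine or a carboxylic acid would read at this nitrogen.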